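The compounds below may be only part of what the source reports. "The series", "measured", "known", "first", "only" and "open" are said of these compounds alone.

For the measured compounds named here, in a functional assay on HeLa cells (Homo sapiens) for cytotoxicity, read by MTT assay, with a stated time of 72 h (a higher number here means a weaker inhibitor, a lower number a stronger inhibitor), compound 1 (`O=C(/C=C/c1cccc(Cl)c1Cl)Nc1cc2c(Nc3ccc(F)c(Cl)c3)ncnc2cc1O[C@H]1CCOC1`) gives 30500 nM as one of only two numbers at hand. Compound 3 (`O=C(/C=C/c1cc(Br)c(O)c(Br)c1)Nc1cc2c(Nc3ccc(F)c(Cl)c3)ncnc2cc1O[C@H]1CCOC1`) gives 27700 nM and lies within the scatter of compound 1, so the two cannot be ranked. Going by the values given here, for compound 2 (`COc1cc2ncnc(Nc3ccc(F)c(Cl)c3)c2cc1NC(=O)/C=C/c1ccccc1[N+](=O)[O-]`) the entry reads "not determined" (no result reported) and yields no step.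

The step to compound 4 (`O=C(/C=C/c1ccccc1[N+](=O)[O-])Nc1cc2c(Nc3ccc(F)c(Cl)c3)ncnc2cc1O[C@H]1CCOC1`) puts 2-nitrophenyl in place of 2,3-dichlorophenyl on a double-bonded chain carbon bound to a double-bonded chain carbon and leaves the rest of compound 1 unchanged. Among the compounds with values here, one measured step bears on it, at that same place: 3,5-dibromo-4-hydroxyphenyl in place of 2,3-dichlorophenyl gave a 1.1-fold lower number from compound 1 to compound 3 (0.04 log units; within the scatter) and so nothing beyond the scatter. This single step is thin evidence, and no number is available for the entering group. A step beyond the scatter in this assay is therefore not expected, and no direction is favoured. The expected change is a 1.1-fold lower number from compound 1 to compound 4 (0.04 log units; within the scatter) and stays within the scatter. Compound 4 is expected at 28000 nM with 12000 nM to 60000 nM as the estimated range.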

Compound 4, half-maximal inhibitory concentration: 29600 nM
Compound 4: middle estimate off by 1.1-fold (0.02 log units), on the low side, and the stated range covers the measured number.
By their numbers in this assay, from the lowest: compounds 3, 4 and 1 (each within the scatter of the next).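

In this assay, the 2-nitrophenyl group replaces both halogen-bearing groups without a step beyond the scatter: a 1.0-fold lower number from compound 1 to compound 4 (0.01 log units; within the scatter), and a 1.1-fold higher number from compound 3 to compound 4 (0.03 log units; within the scatter). This extends the earlier finding at this place on the double-bonded chain carbon, since a phenyl group carrying nitrogen and oxygen rather than chlorine or bromine now also cannot be told apart from the other two, and compounds 1, 3 and 4 all lie within the scatter of one another. No measurement is available that would explain why these three groups cannot be told apart.

On these data alone, all three measured groups are substituted phenyl rings on the same ethenyl link and the same core, so it remains open whether an amine or a carboxylic acid on that ring, or a longer chain in place of the ethenyl link, would give a step beyond the scatter. As far as these compounds go, it also remains open whether these groups would still be indistinguishable in a measurement other than this assay.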